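Removing the iodo group from compound 3

The compounds below may be only part of what the source reports. "The series", "measured", "known", "first", "only" and "open" are said of these compounds alone.

- Compound 1 `Nc1ccn(/C=C/C=O)c(=O)n1`: > 100000 nM, a limit of the assay
- Compound 2 `O=C/C=C/n1ccc(=O)[nH]c1=O`: 30000 nM
- Compound 3 `O=C/C=C/n1c(=O)c(I)cn([C@H]2C[C@H](O)[C@@H](CO)O2)c1=O`: 80000 nM

In a functional assay on HeLa cells (Homo sapiens) for inhibition (on this read-out lower numbers stand for stronger inhibition and higher numbers for weaker inhibition), compound 3 gives 80000 nM, the higher of the two actual numbers. Compound 2 reads lower at 30000 nM, a gap beyond the usual scatter. The next molecule, compound 4 `O=C/C=C/n1c(=O)ccn([C@H]2C[C@H](O)[C@@H](CO)O2)c1=O`, differs from compound 3 by one swap: hydrogen in place of iodo on an aromatic carbon. Among the compounds with values here, no measured pair shows this swap, so the starting point is compound 3 at 80000 nM, and no shift beyond the scatter is expected, in either direction. The estimated change is a 1.1-fold lower number from compound 3 to compound 4 (0.06 log units; within the scatter). Compound 4 is expected at 70000 nM, with an estimated range of 25000 nM to 200000 nM.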

Compound 4, half-maximal inhibitory concentration: 15000 nM
Beside the measured number, compound 4's estimate is 4.7-fold (0.67 log units) above it, and the stated range ends above it.
By their numbers in this assay, from the lowest: compounds 4 and 2 (each within the scatter of the next); then compound 3. At a limit, above all of these: compound 1.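

In this assay, swapping the iodo group for hydrogen gives a 5.3-fold lower number from compound 3 to compound 4 (0.73 log units; beyond the scatter), so this aromatic carbon is not a silent position: what sits there clearly changes the read-out. In this single pair, the compound without iodo inhibits more strongly, though one pair cannot establish a general rule. Nothing measured here explains the shift.

Still open, on these data alone, is how a chlorine, a methyl group or an amine at this position would read relative to compound 3 and compound 4. As far as these compounds go, whether the same swap would have a similar effect on other cores also remains unknown.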